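The compounds below may be only part of what the source reports. "The series", "measured", "known", "first", "only" and "open" are said of these compounds alone.

Compound 2 `COc1cccc(C=C2C(=O)N(c3ccc(Cl)cc3)N(c3ccc(Cl)cc3)C2=O)c1O` gives 26700 nM in a functional assay on MCF7 cells (Homo sapiens) for cytotoxicity, read by MTT assay, with a stated time of 72 h (a lower number here means a stronger inhibitor, a higher number a weaker inhibitor), the smaller of the two numbers recorded so far, with compound 1 `O=C1C(=Cc2ccc(Br)cc2)C(=O)N(c2ccc(Cl)cc2)N1c1ccc(Cl)cc1` nearest at 30400 nM; the gap between the two lies within the scatter. Compound 3 `O=C1C(=Cc2c[nH]c3ccccc23)C(=O)N(c2ccc(Cl)cc2)N1c1ccc(Cl)cc1` has not yet been measured in this assay. It differs from compound 2 in one place: 1H-indol-3-yl in place of 2-hydroxy-3-methoxyphenyl on a double-bonded chain carbon bound to a double-bonded ring carbon. Within the data shown here, only one measured step bears on swapping the group at that double-bonded chain carbon: a 1.1-fold lower number from compound 1 to compound 2 (0.06 log units; within the scatter), a change too small to count. Among the measured compounds shown here, no measured compound carries a 1H-indol-3-yl group, so nothing shows how that group itself behaves here. On this footing the step of a 1.1-fold lower number from compound 2 to compound 3 (0.03 log units; within the scatter) is expected to remain within the scatter. Compound 3 is therefore estimated at 25000 nM in this assay, with a likely range from 8000 nM to 80000 nM.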

Compound 3, half-maximal inhibitory concentration: 34200 nM
Compound 3: middle estimate off by 1.4-fold (0.14 log units), on the low side, and the stated range covers the measured number.
By their numbers in this assay, from the lowest: compounds 2, 1 and 3 (each within the scatter of the next).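

The step of a 1.3-fold higher number from compound 2 to compound 3 (0.11 log units; within the scatter) comes with 1H-indol-3-yl in place of 2-hydroxy-3-methoxyphenyl, and the step of a 1.1-fold higher number from compound 1 to compound 3 (0.05 log units; within the scatter) comes with the same group in place of 4-bromophenyl, both on a double-bonded chain carbon bound to a double-bonded ring carbon. In this assay, among these compounds, this place has now taken a group with a five-membered aromatic ring as well as a six-membered one, and no pair of the three compounds stands beyond the scatter.

On these data alone, all three compounds still carry an aromatic group at this place, so it remains open whether an amine, a carboxylic acid or a longer chain there would shift the number beyond the scatter. The rest of the core is the same throughout, so the compounds say nothing about changes elsewhere. No supporting evidence on these results is available.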